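Aminopyrimidine nitrogen substituent: cyclohexyl in place of hydroxyethyl

The source may hold more compounds than are shown below. What is called first, only, known or untested is meant among the compounds shown, and "the series" means these compounds.

Measured compounds:
compound 1 `Cc1ccc(Nc2ncc3c(n2)N(Cc2ccccc2)C(=O)N(c2cc(NC(=O)c4ccc(C)c(C(F)(F)F)c4)ccc2C)C3)cn1`, in an ADME assay on BaF3 cells (Mus musculus) for inhibition, read by CellTiter-Glo, with a stated time of 72 h (a lower number here means a stronger inhibitor of growth, a higher number a weaker inhibitor of growth), compound 1 gives > 5000 nM, which is a limit of the assay and not a number
compound 2 `Cc1ccc(NC(=O)c2cccc(C(F)(F)F)c2)cc1N1Cc2cnc(Nc3cnn(C)c3)nc2N(C)C1=O`, compound 2 gives 352 nM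
compound 3 `Cc1ccc(NC(=O)c2cccc(C(F)(F)F)c2)cc1N1Cc2cnc(NCCO)nc2N(C)C1=O`, compound 3 gives 3290 nM

Compound 3 stands highest of the two numbers shown. Within the data shown here, its nearest neighbour is compound 2, and the single measured step between them, a 9.3-fold higher number from compound 2 to compound 3 (0.97 log units; beyond the scatter), is beyond the scatter. The value of compound 1 is a limit only, (the limit of > 5000 nM in this assay, at which 1 of the 3 values shown sits), and gives no number to compare against.

Compound 4 `Cc1ccc(NC(=O)c2cccc(C(F)(F)F)c2)cc1N1Cc2cnc(NC3CCCCC3)nc2N(C)C1=O` differs from compound 3 in one place: cyclohexyl in place of 2-hydroxyethyl on a nitrogen on an aromatic ring. Among the measured compounds shown here, the only measured step at this nitrogen is a 9.3-fold higher number from compound 2 to compound 3 (0.97 log units; beyond the scatter), which exchanged an aromatic substituent for the 2-hydroxyethyl; neither side of that step carries a cyclohexyl, so it tells only that a change at this position can move the number by about that size, in either direction. Compound 4 removes the donor and acceptor of the 2-hydroxyethyl and brings in a six-membered non-aromatic ring of carbon only, which is not the same kind of change as the one measured.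

On that basis the expectation for compound 4 is a moderate lowering, a 2.2-fold lower number from compound 3 to compound 4 (0.34 log units; beyond the scatter), with wide uncertainty. The estimated value for compound 4 is 1500 nM, within a range from 400 nM to 6000 nM.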

Compound 4, concentration for 50% growth inhibition: 5220 nM
Estimate against measurement, compound 4: 3.5-fold (0.54 log units) below; measured number inside the range.
By their numbers in this assay, from the lowest: compound 2; then compounds 3 and 4 (each within the scatter of the next).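

In this assay there is a 1.6-fold higher number from compound 3 to compound 4 (0.20 log units; within the scatter), so on this nitrogen cyclohexyl and 2-hydroxyethyl cannot be told apart, even though the hydrogen-bond donor and acceptor of the 2-hydroxyethyl are gone and a six-membered non-aromatic ring of carbon only has entered. Against the 1-methyl-1H-pyrazol-4-yl of compound 2 there is a 15-fold higher number from compound 2 to compound 4 (1.17 log units; beyond the scatter), which stands with a 9.3-fold higher number from compound 2 to compound 3 (0.97 log units; beyond the scatter) as a second step in the same direction: among these three compounds, both non-aromatic substituents give higher numbers than the aromatic one, and none of the three goes against this. Nothing given here bears on why the substituents at this position order as they do.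

On these data alone, whether the lower number of compound 2 belongs to aromatic rings on this nitrogen in general or to this particular ring stays open, and a phenyl, an unmethylated pyrazol-4-yl or a 2-(dimethylamino)ethyl chain at the same place would each bear on that. Among these compounds, compound 1 gives > 5000 nM, which is a limit and not a number, and it differs from the others in more than one place, so no step to it can be read.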